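Replacing 1,3-thiazol-2-yl with 1H-imidazol-2-yl in Compound 2

The source may hold more compounds than are shown below. What is called first, only, known or untested is meant among the compounds shown, and "the series" means these compounds.

In a functional assay on A549 cells (Homo sapiens) for inhibition, read by MTT assay and WST assay, with a stated time of 72 h, tested at 10 uM (on this read-out higher numbers stand for more inhibition of growth at the one concentration tested and lower numbers for less inhibition of growth), compound 1 `Cc1ccc(NC(=O)Nc2ccc(Oc3ccc(-c4nccs4)cc3)cc2)cc1` gives 15.6%, and compound 2 `CC(=O)Oc1sccc1NC(=O)Nc1ccc(Oc2ccc(-c3nccs3)cc2)cc1` gives 6.78%. Going by the values given here, compound 2 thus holds the lower of the two numbers, but the only step at hand, a number 8.8 percentage points lower from compound 1 to compound 2 (within the scatter), lies within the scatter, so the two compounds cannot be ranked against each other.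

Compound 3 `CC(=O)Oc1sccc1NC(=O)Nc1ccc(Oc2ccc(-c3ncc[nH]3)cc2)cc1` keeps everything of compound 2 except one group: 1H-imidazol-2-yl in place of 1,3-thiazol-2-yl on an aromatic carbon. Among the compounds with values here, the single measured step concerns a different part of the molecule, the group on the amide-type nitrogen, so no measured step bears on this exchange, and the two values of compounds 1 and 2 offer no hint about it. With nothing pointing either way, no step beyond the scatter is expected: a number 1.2 percentage points higher from compound 2 to compound 3 (within the scatter). For compound 3 the estimated value in this assay is 8%, with an expected range from -6% to 24%.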

Compound 3, percent growth inhibition at one concentration: 2.34%
Compound 3: middle estimate off by 5.7 percentage points, on the high side; the range from low to high includes it.
By their numbers in this assay, from the lowest: compounds 3, 2 and 1 (each within the scatter of the next, the first and the last beyond it).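

In this assay, going by these compounds alone, this is the first measured exchange at this position, and it gives a number 4.4 percentage points lower from compound 2 to compound 3 (within the scatter), so compound 2 and compound 3 cannot be ranked against each other. Sulfur gives way to a second nitrogen, and the ring gains a hydrogen-bond donor and has one acceptor fewer, yet on this read-out the two rings on the aromatic carbon, para to a large group, cannot be told apart. No independent measurement is available to explain this result.

Open, on these data alone, is whether a group of another kind at this position, such as a carboxylic acid or an amine in place of the five-membered ring, would move the number beyond the scatter. Also open, as far as these compounds go, is whether 1H-imidazol-2-yl would behave the same way with 4-methylphenyl on the amide-type nitrogen.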